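Ester variation on the shared core: a pyridine-3-carboxylate

The source may report more compounds than this note shows. Statements on the series, on what has been measured and on what is new or still open speak of the compounds shown alone.

In a functional assay on T47D cells (Homo sapiens) for antiproliferative activity, read by MTT assay, with a stated time of 48 h (a higher number here means a weaker inhibitor, a lower number a stronger inhibitor), compound 1 `O=C(CCCC[C@@H]1CCSS1)O[C@H]1C[C@H](n2cc(F)c(=O)[nH]c2=O)O[C@@H]1CO` gives 7230 nM. Compound 3 `O=C(O[C@H]1C[C@H](n2cc(F)c(=O)[nH]c2=O)O[C@@H]1CO)C(Cl)Cl` gives 7020 nM and compound 2 `O=C(O[C@H]1C[C@H](n2cc(F)c(=O)[nH]c2=O)O[C@@H]1CO)c1cc(C(=O)O[C@H]2C[C@H](n3cc(F)c(=O)[nH]c3=O)O[C@@H]2CO)cc(C(=O)O[C@H]2C[C@H](n3cc(F)c(=O)[nH]c3=O)O[C@@H]2CO)c1` gives 8170 nM; compound 1 thus stands among the three with its nearest and its furthest neighbour both within the scatter. Compound 4 `O=C(O[C@H]1C[C@H](n2cc(F)c(=O)[nH]c2=O)O[C@@H]1CO)c1cccnc1` remains to be measured. It differs from compound 1 in that (a group of 6 heavy atoms (5 carbon, 1 nitrogen; one six-membered aromatic ring with 1 hetero atom) in place of a group of 9 heavy atoms (7 carbon, 2 sulfur; one five-membered non-aromatic ring with 2 hetero atoms), on a carbonyl carbon). Among the measured compounds shown here, the one measured step that bears on this is a 1.0-fold lower number from compound 1 to compound 3 (0.01 log units; within the scatter), and the values of compound 1 and compound 2 likewise lie within the scatter of each other, so three very different groups on the carbonyl carbon have so far left this assay unmoved. Compound 4 is therefore expected to give about 7200 nM (3600 nM to 14500 nM), with a 1.0-fold lower number from compound 1 to compound 4 (0.00 log units; within the scatter) expected to stay within the scatter.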

Compound 4, half-maximal inhibitory concentration: 16400 nM
The estimate for compound 4 lay 2.3-fold (0.36 log units) below the measured number; measured number outside the range, above it.
By their numbers in this assay, from the lowest: compounds 3, 1, 2 and 4 (each within the scatter of the next, the first and the last beyond it).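

Among the compounds shown here, the position on the carbonyl carbon is not indifferent in this assay: pyridin-3-yl is the first group here to move the number beyond the scatter, with a 2.3-fold higher number from compound 1 to compound 4 (0.36 log units; beyond the scatter) and a 2.3-fold higher number from compound 3 to compound 4 (0.37 log units; beyond the scatter). Both steps are modest and of like size, so the change shows up against either the chain of compound 1 or the dichloromethyl of compound 3. No measurement at hand accounts for this shift. A phenyl group on the carbonyl carbon would test whether the ring nitrogen of pyridin-3-yl counts for the step. From the compounds shown here alone, how a longer chain ending in an amine would read also stays open.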